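This account rests on a few compounds, and the source may have more. Where it says the series, first, only, none or still open, it means among the compounds named here.

Series notes. Compound 1 `Cc1cc(Nc2cc(-c3ccccc3)[nH]n2)n2nc(SCc3ccc(Cl)cc3)nc2n1` is the reference point for this comparison. In a functional assay on MCF7 cells (Homo sapiens) for inhibition, read by MTT assay, with a stated time of 72 h (on this read-out higher numbers stand for weaker inhibition and lower numbers for stronger inhibition), compound 1 gives 8260 nM, the second highest of the three numbers in hand; its nearest neighbour is compound 2 and its furthest is compound 3, both within the scatter. Compound 2 `Cc1nc2nc(SCc3ccc(Cl)cc3)nn2c(Nc2cc(-c3ccccc3)[nH]n2)c1C` gives 10600 nM in this assay, and the step of a 1.3-fold higher number from compound 1 to compound 2 (0.11 log units; within the scatter) lies within the scatter. Within the data shown here, compound 3 `Cc1cc(Nc2ccn(Cc3ccc(F)cc3)n2)n2nc(SCc3ccc(Br)cc3)nc2n1` gives 4280 nM in this assay; no single-change step joins it to compound 1, and the two numbers sit within the scatter of each other. Compound 4 `Cc1cc(Nc2cc(-c3ccccc3)[nH]n2)n2nc(SCC(=O)c3ccccc3)nc2n1` has not yet been measured. It differs from compound 1 as follows: benzoyl in place of 4-chlorophenyl on a saturated chain carbon bound to a sulfur. Among the measured compounds shown here, the one measured step, from compound 1 to compound 2, concerns a methyl on an aromatic carbon and does not touch the saturated chain carbon bound to sulfur; no measured pair bears on exchanging 4-chlorophenyl for benzoyl there. For the measured compounds named here, with no guiding step, no change beyond the scatter is expected, and compound 4 is expected near 8500 nM in this assay, within a range from 3000 nM to 25000 nM. This amounts to an expected step of a 1.0-fold higher number from compound 1 to compound 4 (0.01 log units; within the scatter).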

Compound 4, half-maximal inhibitory concentration: 5240 nM
Beside the measured number, compound 4's estimate is 1.6-fold (0.21 log units) above it, within the range that was stated.
By their numbers in this assay, from the lowest: compounds 3, 4, 1 and 2 (each within the scatter of the next, the first and the last beyond it).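

Working notes on the position: on a saturated chain carbon bound to a sulfur, the exchange of 4-chlorophenyl for benzoyl gives, in this assay, a 1.6-fold lower number from compound 1 to compound 4 (0.20 log units; within the scatter). This is the only measured change at this place among the compounds shown, and it shows that the number stays within the scatter when the chlorine leaves and a carbonyl, with its one hydrogen-bond acceptor, enters. No measurement at hand explains this outcome.

The exchange alters the chlorine and the carbonyl together, so the compounds shown cannot separate the two. Also open, as far as these compounds go, is how the number responds at this place to an amine, a carboxylic acid or a longer chain.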